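A few compounds are considered here, and "the series" means these few. Any claim that something is new, unique, unknown or untested is made for them only; others in the source may bear on it.

Measured so far:
compound 1 `COc1ccc(N2CCN(C(=O)c3nc4cc(Cl)ccc4s3)CC2)cc1` — 42.8%
compound 2 `CCOC(=O)c1nc2cc(C(F)(F)F)ccc2s1` — 29.1%
compound 3 `CC(=O)N1CCN(C(=O)c2nc3cc(C(F)(F)F)ccc3s2)CC1` — 20.2%

In an ADME assay on RAW264.7 cells (Mus musculus) for cytotoxicity, read by MTT assay, with a stated time of 72 h, tested at 50 ug/mL (on this read-out lower numbers stand for less inhibition and higher numbers for more inhibition at the one concentration tested (going by the name of the read-out)), compound 3 gives 20.2%, the lowest of the three numbers; compound 2 lies within the scatter of it, while compound 1 lies beyond the scatter above it. Compound 4 `COc1ccc(N2CCN(C(=O)c3nc4cc(C(F)(F)F)ccc4s3)CC2)cc1` is not yet measured. It differs from compound 3 as follows: 4-methoxyphenyl in place of acetyl on an amine nitrogen in a ring. Compound 1 carries the same 4-methoxyphenyl on the same ring nitrogen, and in this assay compound 1 gives 42.8%. A step upward beyond the scatter is therefore expected. The expected step is a number 19.8 percentage points higher from compound 3 to compound 4 (beyond the scatter). For compound 4 the estimate in this assay is 40%, with a range from 26% to 54%.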

Compound 4, a percentage reported as inhibition, at one concentration (the size of the read-out at that concentration, not a potency): 19.4%
Estimate against measurement, compound 4: 20.6 percentage points above, outside the stated range (below it).
By their numbers in this assay, from the lowest: compounds 4, 3 and 2 (each within the scatter of the next); then compound 1.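

In this assay, 4-methoxyphenyl in place of acetyl on the amine nitrogen in the ring gives a number 0.8 percentage points lower from compound 3 to compound 4 (within the scatter) with trifluoromethyl on the aromatic carbon, so this position takes the larger aromatic group without a readable difference here. Trifluoromethyl in place of chloro on the aromatic carbon gives a number 23.4 percentage points lower from compound 1 to compound 4 (beyond the scatter) with the 4-methoxyphenyl held constant, so that group alone does not fix the number. No measured evidence on these compounds accounts for either step.

Going by these compounds, whether the step between chloro and trifluoromethyl also holds with acetyl on the ring nitrogen remains open. Also open, on these data alone, is how a carboxylic acid or a primary amine on a chain at that nitrogen would read.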